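A few compounds are considered here, and "the series" means these few. Any claim that something is new, unique, unknown or untested is made for them only; others in the source may bear on it.

Measured so far:
Compound 1 `O=c1c2c(sn1-c1ccc(Cl)cc1)CCCC2` — 20400 nM
Compound 2 `O=C1C2=C(CCCC2)S(=O)(=O)N1c1ccc(Cl)cc1` — 8510 nM
Compound 3 `O=c1c2c(sn1-c1ccc(Cl)cc1C(F)(F)F)CCCC2` — 55000 nM

In a functional assay on the whole organism for inhibition, with Scenedesmus acutus as the target, with a stated time of 20 min (a higher number here means a weaker inhibitor, a lower number a stronger inhibitor), compound 3 stands highest of the three, meaning it is the weakest inhibitor; compound 1 is the nearest, and compound 2 gives the lowest number of all.

Compound 4 `O=c1c2c(sn1-c1ccc(Cl)cc1F)CCCC2` differs from compound 3 by fluoro in place of trifluoromethyl on an aromatic carbon. Going by the values given here, the one step that bears on this is a 2.7-fold higher number from compound 1 to compound 3 (0.43 log units; beyond the scatter), where trifluoromethyl replaced hydrogen at this same place and weakened inhibition modestly. Fluoro lies between hydrogen and trifluoromethyl by the heavy-atom count shown, so a partial return toward compound 1 is expected. The step is estimated at a 1.8-fold lower number from compound 3 to compound 4 (0.26 log units; within the scatter). Compound 4 is therefore expected to give 30000 nM, within 15000 nM to 60000 nM.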

Compound 4, half-maximal inhibitory concentration: 30200 nM
Estimate against measurement, compound 4: 1.0-fold (0.00 log units) below; low and high end bracket the measured number.
By their numbers in this assay, from the lowest: compound 2; then compounds 1, 4 and 3 (each within the scatter of the next, the first and the last beyond it).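

In this assay, fluoro in place of trifluoromethyl gives a 1.8-fold lower number from compound 3 to compound 4 (0.26 log units; within the scatter), while fluoro in place of hydrogen gives a 1.5-fold higher number from compound 1 to compound 4 (0.17 log units; within the scatter). Fluoro on this aromatic carbon therefore cannot be told apart from either neighbouring result, even though hydrogen and trifluoromethyl themselves differ beyond the scatter. No supporting measurement is available to explain these numbers.

Still open, from the compounds shown here alone, is whether a methoxy group or an amine on this same carbon would shift the number beyond the scatter. Also open, going by these compounds, is whether fluoro would behave alike on the core of compound 2.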